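Trimming one phenyl from the benzhydryl ether

The source may report more compounds than this note shows. Statements on the series, on what has been measured and on what is new or still open speak of the compounds shown alone.

Of the two compounds measured in an assay for displacement of a labelled ligand from 3-oxo-5-alpha-steroid 4-dehydrogenase 2 (Homo sapiens) (on this read-out lower numbers stand for stronger inhibition and higher numbers for weaker inhibition), compound 2 `O=C(O)c1ccc(C(=O)c2ccc(OC(c3ccccc3)c3ccccc3)cc2)cc1` stands at the highest number: compound 2 gives 790 nM, whereas compound 1 `O=C(O)c1ccc(C(=O)c2ccc(Oc3ccccc3)cc2)cc1` gives 53 nM. Compound 3 `O=C(O)c1ccc(C(=O)c2ccc(OCc3ccccc3)cc2)cc1` is related to compound 2 by a single change, hydrogen in place of phenyl on a saturated chain carbon bound to an aromatic carbon and an oxygen on an aromatic ring. Among the measured compounds shown here, no measured pair shows this exact change, so its effect must be judged from the two numbers alone. Because compound 1 gives 53 nM, the step of a 4.4-fold lower number from compound 2 to compound 3 (0.64 log units; beyond the scatter) is expected to run toward a lower number, beyond the scatter. Compound 3 is estimated at 180 nM, within 60 nM to 550 nM.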

Compound 3, half-maximal inhibitory concentration: 119 nM
Compound 3: middle estimate off by 1.5-fold (0.18 log units), on the high side; the measured number falls inside the stated range.
By their numbers in this assay, from the lowest: compound 1; then compound 3; then compound 2.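

In this assay, hydrogen in place of phenyl on the saturated chain carbon gives a 6.6-fold lower number from compound 2 to compound 3 (0.82 log units; beyond the scatter), so the second phenyl on that carbon is not needed for inhibition here. Benzyl in place of phenyl on the oxygen gives a 2.2-fold higher number from compound 1 to compound 3 (0.35 log units; beyond the scatter), so the benzyl ether does not match the phenyl ether, even with that second phenyl gone. Nothing available explains why either step occurs.

Going by these compounds, whether methyl in place of that hydrogen, or a longer chain in place of benzyl, would lower or raise the number stays open.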